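A few compounds are considered here, and "the series" means these few. Any claim that something is new, unique, unknown or untested is made for them only; others in the source may bear on it.

Compounds measured in an ADME assay on HUVEC cells (Homo sapiens) for cytotoxicity, read by MTT assay, with a stated time of 72 h; on this read-out lower numbers stand for stronger inhibition and higher numbers for weaker inhibition:
- compound 1 `COc1cc(-c2nccn2CC(C)C)cc(OC)c1OC`: "not determined" (no result reported)
- compound 2 `COc1cc(-c2nccn2S(=O)(=O)c2ccc(C)cc2)cc(OC)c1OC`: "not determined" (no result reported)
- compound 3 `COc1cc(-c2nccn2-c2cccc([N+](=O)[O-])c2)cc(OC)c1OC`: > 100000 nM

Compound 1 has no single number to stand on: its entry in this assay reads "not determined" (no result reported). Compound 2 is in the same position, with "not determined" (no result reported). The only reported result in the series belongs to compound 3, and its > 100000 nM is a limit of the assay, not a number. For the measured compounds named here, that leaves the limit of > 100000 nM in this assay, at which 1 of the 3 values shown sits, as the sole evidence.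

The step to follow leads to compound 4 `COc1cc(-c2nccn2-c2ccc(Br)cc2)cc(OC)c1OC` and is 4-bromophenyl in place of isobutyl on an aromatic nitrogen. In words, 4-bromophenyl takes the place of isobutyl on an aromatic nitrogen. On these data alone, with no number for compound 1, the size of this step in this assay cannot be read from the data, and its direction stays open. The nearest guide is compound 3, which also has a six-membered aromatic ring of carbon only on that nitrogen and which reached only the limit of > 100000 nM. A reading for compound 4 at the weak end of the scale, close to that limit, is therefore expected, and it may again be reported only as a limit. Compound 4 is estimated at 60000 nM, with an expected range from 20000 nM to 100000 nM.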

Compound 4, half-maximal inhibitory concentration: > 100000 nM
Compound 4 ended at the assay's limit; the forecaster's own chance of this, stated with the estimate: 55%; middle value at least 1.6-fold (0.22 log units) away from the limit.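

No new step can be read between compound 1 and compound 4: compound 1 has no single number in this assay, and compound 4 gives > 100000 nM, a limit of the assay and not a number. The compounds shown leave open whether any group on the aromatic nitrogen gives a single number in this assay, and the series so far rests on this: the limit of > 100000 nM in this assay, at which 2 of the 4 values shown sit.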